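Replacing furan-2-yl with 2-methylphenyl on compound 2

A few compounds are considered here, and "the series" means these few. Any claim that something is new, unique, unknown or untested is made for them only; others in the source may bear on it.

In a functional assay on HeLa cells (Homo sapiens) for cytotoxicity, read by ELISA, with a stated time of 4 days (a higher number here means a weaker inhibitor, a lower number a stronger inhibitor), compound 1 (`Cc1ccsc1-c1cc(-c2ccoc2)cc(-c2ccco2)n1`) gives 30500 nM, and compound 2 (`Clc1ccc(-c2cc(-c3ccoc3)cc(-c3ccco3)n2)s1`) gives 22700 nM. Among the compounds with values here, these are the only two measurements so far. They lie within the usual scatter of each other, so compound 2 cannot be ranked against compound 1.

Compound 3 (`Cc1ccccc1-c1cc(-c2ccoc2)cc(-c2ccc(Cl)s2)n1`) keeps the 5-chlorothiophen-2-yl and furan-3-yl groups of compound 2 and carries 2-methylphenyl in place of furan-2-yl on an aromatic carbon, next to the ring nitrogen: 2-methylphenyl in place of furan-2-yl on an aromatic carbon.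

Within the data shown here, the one measured step is a 1.3-fold lower number from compound 1 to compound 2 (0.13 log units; within the scatter), with 5-chlorothiophen-2-yl in place of 3-methylthiophen-2-yl. It concerns a different place on the molecule, so it is only a loose guide. Among the measured compounds shown here, no measured compound shows what happens when furan-2-yl is exchanged, which leaves the direction open. For the measured compounds named here, with only that small step from compound 1 to go on, a change of similar size is expected in this assay, and the estimate is a 1.3-fold lower number from compound 2 to compound 3 (0.10 log units; within the scatter). For compound 3 the expected value is 18000 nM, with an estimated range of 6000 nM to 50000 nM.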

Compound 3, half-maximal inhibitory concentration: 19000 nM
The estimate for compound 3 lay 1.1-fold (0.02 log units) below the measured number; the measured number falls inside the stated range.
By their numbers in this assay, from the lowest: compounds 3, 2 and 1 (each within the scatter of the next).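

Within the data shown here, compound 3 is the first compound here in which the furan-2-yl group is exchanged, so it gives the first direct look at this position, next to the ring nitrogen. In this assay, placing 2-methylphenyl there gives a 1.2-fold lower number from compound 2 to compound 3 (0.08 log units; within the scatter), so the numbers of the two compounds cannot be told apart. This holds even though the exchange replaces a five-membered aromatic ring that has one hydrogen-bond acceptor with a larger, six-membered aromatic ring of carbon only that has none, which shows that, for this one pair, the furan-2-yl group can give way to 2-methylphenyl with no difference beyond the usual scatter, and no supporting data are available to explain this result.

As far as these compounds go, it remains open whether a group of a different kind at this position, such as an amine or a carboxylic acid, would move the number beyond the scatter. Also open, from the compounds shown here alone, are what a plain phenyl group would give there, which would show what the methyl group of 2-methylphenyl contributes, and what a longer chain would give in place of the furan-3-yl group.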